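A few compounds are considered here, and "the series" means these few. Any claim that something is new, unique, unknown or untested is made for them only; others in the source may bear on it.

Working notes on the series. In a functional assay on K562 cells (Homo sapiens) for cytotoxicity, read by MTT assay (a higher number here means a weaker inhibitor, a lower number a stronger inhibitor), compound 1 (`CCC(=O)Oc1cc(/C=C/C(=O)c2ccc(OC)c3c2OC(C)(C)C=C3)ccc1OC`) gives 160 nM and compound 2 (`C=CC(=O)Oc1cc(/C=C/C(=O)c2ccc(OC)c3c2OC(C)(C)C=C3)ccc1OC`) gives 300 nM. Only these two numbers are available, and they lie within the scatter of each other, so compound 2 does not stand apart from compound 1. The next structure is compound 3 (`COc1ccc(/C=C/C(=O)c2ccc(OC)c3c2OC(C)(C)C=C3)cc1OC(=O)C1CC1`), and the change is cyclopropyl in place of vinyl on a carbonyl carbon. Among the measured compounds shown here, one measured step bears on it, also on a carbonyl carbon: a 1.9-fold higher number from compound 1 to compound 2 (0.27 log units; within the scatter). For the measured compounds named here, no compound with cyclopropyl has a measured value yet. Going by the values given here, with that single step as the only guide, no step beyond the scatter is expected in this assay, in either direction. The expected step is a 1.4-fold lower number from compound 2 to compound 3 (0.13 log units; within the scatter). Compound 3 is estimated at 220 nM, with an expected range of 90 nM to 550 nM.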

Compound 3, half-maximal inhibitory concentration: 410 nM
Estimate against measurement, compound 3: 1.9-fold (0.27 log units) below, and the stated range covers the measured number.
By their numbers in this assay, from the lowest: compounds 1, 2 and 3 (each within the scatter of the next, the first and the last beyond it).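

Putting cyclopropyl in place of vinyl on this carbonyl carbon gives a 1.4-fold higher number from compound 2 to compound 3 (0.14 log units; within the scatter) in this assay and so does not separate these two compounds. Cyclopropyl in place of ethyl gives a 2.6-fold higher number from compound 1 to compound 3 (0.41 log units; beyond the scatter) and is the first step in the series beyond the scatter, modest in size, which shows that the number in this assay can respond to the group at this position, with compound 3 a weaker inhibitor than compound 1. No measurement at hand accounts for this difference.

The three groups shown span only a narrow range, so it remains open whether a longer chain such as butyl on this carbonyl carbon would stay close to compound 1 or move further from it. On these data alone, an amine at the same place is equally open.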